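A few compounds are considered here, and "the series" means these few. Any claim that something is new, unique, unknown or untested is made for them only; others in the source may bear on it.

Measured so far in an ADME assay on Vero cells (Chlorocebus sabaeus) for cytotoxicity, read by XTT assay, with a stated time of 72 h; a higher number here means that more compound is tolerated, a lower number that less compound is tolerated:

- compound 1 `CC1=C(C(=O)OC(C)(C)C)C(c2cccs2)NC(=O)N1`: > 100000 nM
- compound 2 `CC1=C(C(=O)Nc2cccnc2)C(c2cccs2)NC(=O)N1`: > 100000 nM

The value of compound 1 in this assay is a limit of the assay, not a number. The value of compound 2 in this assay is likewise a limit. The step that the two limits leave unreadable from compound 1 to compound 2 therefore cannot be read as a size; both ends sit at the same limit, as summarised by the limit of > 100000 nM in this assay, at which 2 of the 2 values shown sit. On the numbers shown, compound 2 stands at the limit of this assay, with no measured number placing it either way.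

Compound 3 `CC1=C(C(=O)Nc2cccc(Cl)c2)C(c2cccs2)NC(=O)N1` differs from compound 2 in one place: 3-chlorophenyl in place of pyridin-3-yl on an amide-type nitrogen. Going by the values given here, no measured step changes the group on the amide-type nitrogen from one aromatic ring to another, so the only evidence that bears on the step is the one unreadable step from compound 1 to compound 2, which leaves both ends at the limit. The expectation for the step of a number no higher from compound 2 to compound 3 (the limit leaves the size open) is thus no change beyond the scatter, with the most likely outcome again a limit. Compound 3 is expected to give 100000 nM in this assay, within a range of 30000 nM to 200000 nM.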

Compound 3, half-maximal cytotoxic concentration: > 100000 nM
Compound 3: no number, only a limit; the forecaster's own chance of this, stated with the estimate: 60%; the middle value lies on the limit itself.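

In this assay, going by these compounds alone, compound 3 gives > 100000 nM which is a limit and not a number, so no step from compound 2 to compound 3 can be read. The compounds shown leave open whether any group on the amide-type nitrogen changes the concentration tolerated in this assay at all.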